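Swapping the chain amide for a methoxypyrazine amine

The source may report more compounds than this note shows. Statements on the series, on what has been measured and on what is new or still open speak of the compounds shown alone.

Compound 1 `CCN1CCN(c2cccc3c2CN([C@H](CCCNC(=O)c2cccs2)c2ccc(OC)c(OC)c2)C3=O)CC1` is the starting point. In an assay on RMS13 cells for displacement of a labelled ligand from Urotensin-2 receptor (Homo sapiens), read by scintillation proximity assay (on this read-out lower numbers stand for stronger inhibition and higher numbers for weaker inhibition), compound 1 gives 18 nM, the lowest of the three numbers shown. Compound 2 `COc1ccc([C@@H](CCCN(C)S(=O)(=O)c2cccs2)N2Cc3c(cccc3N3CCNCC3)C2=O)cc1OC` gives 49 nM in this assay, and compound 3 `COc1ccc([C@@H](CCCN(C)S(=O)(=O)c2cccs2)N2Cc3c(cccc3N3CCN(C4CC4)CC3)C2=O)cc1OC` gives 59 nM. Going by the values given here, the one measured step, a 1.2-fold higher number from compound 2 to compound 3 (0.08 log units; within the scatter), concerns the amine nitrogen in a ring of the shared core and not the side chain. Compound 4 `CCN1CCN(c2cccc3c2CN([C@H](CCCNc2cncc(OC)n2)c2ccc(OC)c(OC)c2)C3=O)CC1` differs from compound 1 in one place: 6-methoxypyrazin-2-yl in place of (thiophen-2-yl)carbonyl on an amine nitrogen. Among the compounds with values here, no measured pair shows this exchange, so nothing among the measured compounds sets its size; the only available comparison, between compound 2 and compound 3, touches another part of the molecule and lies within the scatter. Within the data shown here, with no direct precedent, compound 4 is expected to move only modestly toward a higher number, a 1.9-fold higher number from compound 1 to compound 4 (0.29 log units; within the scatter). In this assay compound 4 is estimated at 35 nM, with a range from 9 nM to 140 nM.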

Compound 4, inhibition constant: 8 nM
Beside the measured number, compound 4's estimate is 4.4-fold (0.64 log units) above it; the measured number lies below the stated range.
By their numbers in this assay, from the lowest: compound 4; then compound 1; then compounds 2 and 3 (each within the scatter of the next).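

The earlier compounds shown here showed a change only at the amine nitrogen in a ring of the shared core, whereas this pair changes the side-chain amine nitrogen, and in this assay the exchange gives a 2.3-fold lower number from compound 1 to compound 4 (0.35 log units; beyond the scatter) in a step the earlier compounds could not show. In this one pair, the carbonyl on that nitrogen is therefore not required for a low number, since the 6-methoxypyrazin-2-yl group attached directly to the nitrogen gives the lower value.

Going by these compounds, it remains open whether the lower number depends on the pyrazine ring or on its methoxy group, and whether an unsubstituted pyrazin-2-yl, a pyridin-2-yl or an ethoxy in place of the methoxy would hold it. No evidence shown here bears on why the number falls.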